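Series notes: amide-linked sulfamates, change at the aryl amine

A few compounds are considered here, and "the series" means these few. Any claim that something is new, unique, unknown or untested is made for them only; others in the source may bear on it.

Two compounds of this series carry a value in an assay on HEK293 cells for inhibition of Steryl-sulfatase (Homo sapiens), tested at 1 uM; on this read-out lower numbers stand for a weaker effect and higher numbers for a stronger effect at the one concentration tested. Compound 1 `CCN(Cc1cccc(Br)c1)c1cccc(C(=O)N2CCc3ccc(OS(N)(=O)=O)cc3C2)c1` gives 24.9%. Going by the values given here, compound 2 `NS(=O)(=O)Oc1ccc2c(c1)CN(C(=O)c1cccc(N3CCc4ccccc4C3)c1)CC2` gives 50.2%, which is the higher of the two numbers; the only step measured so far, a number 25.3 percentage points higher from compound 1 to compound 2 (beyond the scatter), separates them.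

Compound 3 `CN(CCN1CCCCC1)c1cccc(C(=O)N2CCc3ccc(OS(N)(=O)=O)cc3C2)c1` is not yet measured. It differs from compound 2 by one change: methyl(2-(piperidin-1-yl)ethyl)amino in place of 1,2,3,4-tetrahydroisoquinolin-2-yl on an aromatic carbon, on an aromatic carbon of a six-membered aromatic ring of carbon only, meta to a large group.

Among the compounds with values here, only the step from compound 1 to compound 2 bears on this change, and it bears on it indirectly: there, the 1,2,3,4-tetrahydroisoquinolin-2-yl that compound 3 now loses entered in place of an open amino group and the number rose by a number 25.3 percentage points higher from compound 1 to compound 2 (beyond the scatter). Compound 3 again carries an open amino group, although a different one from that of compound 1. A fall beyond the scatter is therefore expected, though its size is uncertain, estimated as a number 20.2 percentage points lower from compound 2 to compound 3 (beyond the scatter). For compound 3 the expected value in this assay is 30%, with a range from 12% to 50%.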

Compound 3, a percentage reported as inhibition, at one concentration (the size of the read-out at that concentration, not a potency): 30.8%
The estimate for compound 3 lay 0.8 percentage points below the measured number; low and high end bracket the measured number.
By their numbers in this assay, from the lowest: compounds 1 and 3 (each within the scatter of the next); then compound 2.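

Notes on the aryl amine position: in this assay, methyl(2-(piperidin-1-yl)ethyl)amino in place of 1,2,3,4-tetrahydroisoquinolin-2-yl gives a number 19.4 percentage points lower from compound 2 to compound 3 (beyond the scatter), although both groups count 10 heavy atoms, so the heavy-atom count alone does not keep the number of compound 2 at this aromatic carbon. The two open amino groups, which differ widely in their substituents, are not separated: the change from (3-bromobenzyl)(ethyl)amino gives a number 5.9 percentage points higher from compound 1 to compound 3 (within the scatter), so among these three compounds only compound 2, with its 1,2,3,4-tetrahydroisoquinolin-2-yl, stands apart, and neither open amino compound goes against this. No measurement at hand explains why this group differs from the two open amino groups.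

The compounds shown do not separate the closed ring from its aromatic ring, a question that a morpholin-4-yl or pyrrolidin-1-yl group and an open benzyl(methyl)amino group on the same aromatic carbon would address. From the compounds shown here alone, with readings at a single concentration, it also remains open whether these differences carry over to potency.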